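Dropping One Chloro from a Dichloro Fused Core

The source may report more compounds than this note shows. Statements on the series, on what has been measured and on what is new or still open speak of the compounds shown alone.

Compound 1 `ClCc1ccc(Cn2cnc3c(Cl)ncnc32)cc1` carries one chloro on the fused six-membered ring and a chloromethyl group on its benzyl arm; in a functional assay on NCI/ADR-RES cells (Homo sapiens) for cytotoxicity, read by sulforhodamine B assay, with a stated time of 48 h (on this read-out higher numbers stand for weaker inhibition of growth and lower numbers for stronger inhibition of growth), compound 1 gives 1510 nM. Compound 2 `ClCc1ccccc1Cn1cnc2c(Cl)nc(Cl)nc21` has a differently arranged benzyl arm and two chloro groups on the fused ring; in this assay compound 2 gives 1510 nM. Compound 2 thus stands level with compound 1, the two values lying within the scatter.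

Compound 3 `ClCc1ccccc1Cn1cnc2c(Cl)ncnc21` remains to be measured. It differs from compound 2 in one place: hydrogen in place of chloro on an aromatic carbon between two ring nitrogen atoms. Among the compounds with values here, no measured pair shows this change. Because compound 1 gives 1510 nM with one chloro and compound 2 gives 1510 nM with two, only a step within the scatter is expected, in no particular direction. Compound 3 is therefore estimated at 1500 nM, ranging from 500 nM to 4500 nM, an expected step of a 1.0-fold lower number from compound 2 to compound 3 (0.00 log units; within the scatter).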

Compound 3, concentration for 50% growth inhibition: 2180 nM
Estimate against measurement, compound 3: 1.5-fold (0.16 log units) below; the measured number falls inside the stated range.
By their numbers in this assay, from the lowest: compounds 1, 2 and 3 (each within the scatter of the next).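

Direct comparison at this position comes only from compound 2 and compound 3, which differ solely by hydrogen in place of chloro on the aromatic carbon between two ring nitrogen atoms. In this assay, this change gives a 1.4-fold higher number from compound 2 to compound 3 (0.16 log units; within the scatter), so the chloro group at this position makes no difference beyond the scatter in this pair. Nothing among the data accounts for this result or links it to any property of the chloro group.

The compounds shown leave open whether an amine or a methoxy group on this carbon would move the number beyond the scatter. They also leave open what would follow if the chloro group on the other aromatic carbon of that ring gave way to hydrogen or an amine.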